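A Hydroxy Group Added to the Weakest Compound

The source may hold more compounds than are shown below. What is called first, only, known or untested is meant among the compounds shown, and "the series" means these compounds.

Compound 1, `O=C(Nc1ccc(I)cc1)c1ccc(C(=O)C(F)(F)F)cc1`, gives 790 nM in a functional assay on HEK293 cells for antagonist activity at transient receptor potential cation channel subfamily V member 1 (Homo sapiens), read by calcium flux; a lower number here means a stronger inhibitor, a higher number a weaker inhibitor.
Compound 2, `O=C(Nc1ccc2c(c1)CCC2)c1ccc(OC(F)(F)F)cc1`, gives 210 nM in this assay.
Compound 3, `O=C(NCCN1CCCc2ccccc21)c1ccc(OC(F)(F)F)cc1`, gives 4600 nM in this assay.

Among these three, compound 3 has the highest number in this assay and is therefore the weakest inhibitor. Compound 1 stands nearest to it, with a lower number that lies beyond the usual scatter, and compound 2 stands furthest away, with a still lower number that also lies beyond the scatter.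

Compound 4, `O=C(NCCN1CCCc2ccc(O)cc21)c1ccc(OC(F)(F)F)cc1`, differs from compound 3 in one place: hydroxy in place of hydrogen on an aromatic carbon. Within the data shown here, no measured pair in this set shows the same change, so its effect is unknown from the data alone. Because compound 3 gives 4600 nM, a moderate move toward a lower number in this assay is expected rather than a large one: the expected step is a 2.3-fold lower number from compound 3 to compound 4 (0.36 log units; beyond the scatter). For compound 4 the estimated value in this assay is 2000 nM, with a range from 500 nM to 8000 nM.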

Compound 4, half-maximal inhibitory concentration: 960 nM
Compound 4: the middle estimate sits 2.1-fold (0.32 log units) above what was measured, within the range that was stated.
By their numbers in this assay, from the lowest: compound 2; then compounds 1 and 4 (each within the scatter of the next); then compound 3.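

Hydroxy in place of hydrogen on an aromatic carbon of the fused system, para to a fused ring, gives a 4.8-fold lower number from compound 3 to compound 4 (0.68 log units; beyond the scatter) in this assay. Among these compounds, this is the first comparison in the set between two compounds that differ in one place, and it shows that this carbon is sensitive to substitution: adding a single oxygen makes the inhibitor modestly but clearly stronger. The data available here offer no measurement that explains why the number falls at this position.

As far as these compounds go, it remains open whether this step is specific to hydroxy or would also appear with another small group at the same carbon, such as methoxy, fluorine or an amine. The compounds shown also leave open whether hydroxy on a different aromatic carbon of that ring would give a similar step.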